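The source may report more compounds than this note shows. Statements on the series, on what has been measured and on what is new or still open speak of the compounds shown alone.

Working notes on the thiophene-derived series.

Among the compounds with a number in a functional assay on NCI/ADR-RES cells (Homo sapiens) for inhibition, read by sulforhodamine B assay, with a stated time of 48 h (on this read-out lower numbers stand for stronger inhibition of growth and higher numbers for weaker inhibition of growth), compound 3 `S=C(N/N=C/c1cccs1)Nc1ccc(Cl)cc1` stands lowest, with 2800 nM. Its nearest neighbour is compound 2 `Cc1ccc(NC(=S)N/N=C/c2cccs2)cc1`, which in this assay gives 4800 nM; the gap between the two is within the scatter, so no order is claimed between them. Compound 1 `CCc1ccc(NC(=S)N/N=C/c2cccs2)cc1` returns only a limit in this assay, > 100000 nM, and not a number (the limit of > 100000 nM in this assay, at which 1 of the 3 values shown sits).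

Compound 4 `S=C(N/N=C/c1cccs1)Nc1ccc(Br)cc1` is not yet measured. It differs from compound 3 in one place: bromo in place of chloro on an aromatic carbon.

Of the measured steps, the one nearest in kind is a 1.7-fold lower number from compound 2 to compound 3 (0.23 log units; within the scatter), an exchange of one small substituent for another on the same aromatic carbon, which stayed within the scatter. The larger steps, an at least 20-fold lower number from compound 1 to compound 2 (1.31 log units; beyond the scatter) and an at least 35-fold lower number from compound 1 to compound 3 (1.55 log units; beyond the scatter), both start from the ethyl compound and do not bear on a halogen exchange. Going by the values given here, no step here swaps one halogen for another.

The expected step is therefore a 1.1-fold lower number from compound 3 to compound 4 (0.05 log units; within the scatter), none beyond the scatter. Compound 4 is estimated at 2500 nM in this assay, with a range from 900 nM to 7000 nM.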

Compound 4, concentration for 50% growth inhibition: 1700 nM
Compound 4: middle estimate off by 1.5-fold (0.17 log units), on the high side; measured number inside the range.
By their numbers in this assay, from the lowest: compounds 4, 3 and 2 (each within the scatter of the next, the first and the last beyond it). At a limit, above all of these: compound 1.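

In this assay, the only exchange of one halogen for another shown at this aromatic carbon, para to a large group, stays within the scatter (a 1.6-fold lower number from compound 3 to compound 4 (0.22 log units; within the scatter)), so chloro and bromo are not told apart here. Against methyl, however, bromo gives a step beyond the scatter (a 2.8-fold lower number from compound 2 to compound 4 (0.45 log units; beyond the scatter)), whereas chloro did not, although compound 3 lies within the scatter of both compound 2 and compound 4. Compound 1 remains a limit and not a number, and the step (an at least 58-fold lower number from compound 1 to compound 4 (1.76 log units; beyond the scatter)) sets the ethyl compound well apart from the bromo compound: (the limit of > 100000 nM in this assay, at which 1 of the 4 values shown sits).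

From the compounds shown here alone, what iodo or fluoro would give on this carbon stays open, as does the effect of an amine or a carboxylic acid there. Going by these compounds, whether a longer chain such as propyl follows ethyl also remains unknown.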